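Halogen swap on the aryl group of compound 2

The compounds below may be only part of what the source reports. "The series", "measured", "known", "first", "only" and "open" are said of these compounds alone.

Measured in an ADME assay on Vero cells (Chlorocebus sabaeus) for cytotoxicity, read by MTT assay, with a stated time of 72 h; a higher number here means that more compound is tolerated, a lower number that less compound is tolerated
Compound 1 `CN(C)c1ccc(/C=C/C(=O)c2ccc3c(c2O)C=CC(C)(C)O3)cc1` gives > 400000 nM (a limit of the assay)
Compound 2 `CC1(C)C=Cc2c(ccc(C(=O)/C=C/c3ccc(F)cc3)c2O)O1` gives 158000 nM
Compound 3 `CC1(C)C=Cc2c(ccc(C(=O)/C=C/c3ccc(F)c(F)c3)c2O)O1` gives 146000 nM

Compound 1 is reported only as a limit (> 400000 nM). That leaves two actual numbers in this assay, and compound 2 stands level with compound 3, with a 1.1-fold lower number from compound 2 to compound 3 (0.03 log units; within the scatter) between them.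

Compound 4 (`CC1(C)C=Cc2c(ccc(C(=O)/C=C/c3ccc(Cl)c(Cl)c3)c2O)O1`) is not yet measured. It carries 3,4-dichlorophenyl in place of 4-fluorophenyl on a double-bonded chain carbon bound to a double-bonded chain carbon.

Among the measured compounds shown here, two measured steps bear on this change. The closer one is a 1.1-fold lower number from compound 2 to compound 3 (0.03 log units; within the scatter), which puts fluoro in place of hydrogen on an aromatic carbon. The other is an at least 2.5-fold lower number from compound 1 to compound 2 (0.40 log units; beyond the scatter), which replaces dimethylamino and so is a much less direct guide. For the measured compounds named here, no chloro compound has been measured yet. A step beyond the scatter is therefore not expected, though a slightly lower number is the likelier direction.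

The expected step is a 1.4-fold lower number from compound 2 to compound 4 (0.16 log units; within the scatter) in this estimate. Compound 4 is expected at 110000 nM (estimated range 45000 nM to 220000 nM).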

Compound 4, half-maximal cytotoxic concentration: 142000 nM
For compound 4 the middle estimate is 1.3-fold (0.11 log units) below the measured one, within the range that was stated.
By their numbers in this assay, from the lowest: compounds 4, 3 and 2 (each within the scatter of the next). At a limit, above all of these: compound 1.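

In this assay, 3,4-dichlorophenyl on a double-bonded chain carbon bound to a double-bonded chain carbon reads level with 4-fluorophenyl, at a 1.1-fold lower number from compound 2 to compound 4 (0.05 log units; within the scatter), and level with 3,4-difluorophenyl, at a 1.0-fold lower number from compound 3 to compound 4 (0.01 log units; within the scatter). The earlier fluoro pair covered only the addition of a second fluoro, whereas these steps extend the flat reading to chloro, with no separation among the three halogenated compounds in this set. Compound 1, carrying dimethylamino, gives a limit of the assay, > 400000 nM: the limit of > 400000 nM in this assay, at which 1 of the 4 values shown sits.

On these data alone, whether the flat reading holds for non-halogen groups on this aryl ring, such as methoxy, nitrile or a carboxylic acid, remains open. Also open, as far as these compounds go, is whether an amine other than dimethylamino would stand with compound 1 or with the halogenated compounds.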